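Carbamate Substituent Change and Expected Kinase Inhibition of Compound 3

This account rests on a few compounds, and the source may have more. Where it says the series, first, only, none or still open, it means among the compounds named here.

Among the two measured compounds, compound 2 `COC(=O)N1CCN(C(=O)c2nc(Nc3cc(C4CC4)[nH]n3)c3cc(Cl)ccc3n2)C[C@H]1C` holds the higher number: in an assay for inhibition of serine/threonine-protein kinase PAK 4 (Homo sapiens), read by FRET and Z'-LYTE, with a stated time of 60 min, tested at 5 uM, in the presence of a further agent that is not named here (on this read-out lower numbers stand for a weaker effect and higher numbers for a stronger effect at the one concentration tested), compound 2 gives 89.6%. Among the measured compounds shown here, its only measured neighbour, compound 1 `CCCCCOC(=O)N1CCN(C(=O)c2nc(Nc3cc(C4CC4)[nH]n3)c3cc(Cl)ccc3n2)C[C@H]1C`, in this assay gives 12.6%. For the measured compounds named here, the single measured step, a number 77 percentage points higher from compound 1 to compound 2 (beyond the scatter), shows that what sits on the saturated chain carbon bound to an oxygen next to a carbonyl group matters greatly for this read-out. Compound 3 `C[C@@H]1CN(C(=O)c2nc(Nc3cc(C4CC4)[nH]n3)c3cc(Cl)ccc3n2)CCN1C(=O)OCC(Cl)(Cl)Cl` has not yet been measured. It differs from compound 2 by trichloromethyl in place of hydrogen on a saturated chain carbon bound to an oxygen next to a carbonyl group. Going by the values given here, this change falls at the same place as the measured step and, like the reverse of that step, puts a larger group where compound 2 carries hydrogen; no other measured pair speaks to it. Because a number 77 percentage points higher from compound 1 to compound 2 (beyond the scatter) is large, an addition at this place is expected to lower the number in this assay, although the entering group is not the butyl chain of compound 1, so the size of the drop is uncertain. Compound 3 is therefore estimated at 40%, with a range from 10% to 75%, which means an expected step of a number 49.6 percentage points lower from compound 2 to compound 3 (beyond the scatter).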

Compound 3, a percentage reported as inhibition, at one concentration (the size of the read-out at that concentration, not a potency): 63%
Compound 3: middle estimate off by 23 percentage points, on the low side; the range from low to high includes it.
By their numbers in this assay, from the lowest: compound 1; then compound 3; then compound 2.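

Adding to this place does not by itself abolish the effect in this assay: trichloromethyl in place of hydrogen gives a number 26.6 percentage points lower from compound 2 to compound 3 (beyond the scatter) and is only a modest loss, so compound 3 keeps much of the inhibition seen with compound 2 at the one concentration tested. The identity of the entering group also matters, not merely the fact that something replaces hydrogen, since trichloromethyl in place of butyl at the same saturated chain carbon gives a number 50.4 percentage points higher from compound 1 to compound 3 (beyond the scatter) and this large step leaves compound 3 far closer to compound 2 than compound 1 is. Nothing shown accounts for this difference between the trichloromethyl and butyl groups.

With only hydrogen, trichloromethyl and butyl compared at this place, the compounds shown leave open how a lone methyl, a trifluoromethyl or a shorter chain such as ethyl would read out in this assay and whether the chlorine atoms of compound 3 are needed for the inhibition it keeps. They also leave open whether a chain ending in an amine or a carboxylic acid would be accepted here, and, with a single concentration behind every number, how the three compounds would rank by potency.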